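Swapping the Aryl Group on the Ring Amide Nitrogen

The source may hold more compounds than are shown below. What is called first, only, known or untested is meant among the compounds shown, and "the series" means these compounds.

Compound 1 `CO[C@@H]1CC=C2NN(c3ccc([N+](=O)[O-])cc3)C(=O)CC[C@]2(c2ccccc2)O1` and compound 2 `CO[C@@H]1CC=C2NN(c3ccccn3)C(=O)CC[C@]2(c2ccccc2)O1` share one core and were tested in a functional assay on HCT-116 cells (Homo sapiens) for cytotoxicity, read by sulforhodamine B assay, with a stated time of 48 h; a lower number here means a stronger inhibitor, a higher number a weaker inhibitor. Compound 1 gives 8700 nM, the higher of the two numbers, while compound 2 gives 1400 nM. Within the data shown here, the one measured step, a 6.2-fold lower number from compound 1 to compound 2 (0.79 log units; beyond the scatter), altered this same aryl group. Compound 3 `CO[C@@H]1CC=C2NN(c3cc(Cl)cc(Cl)c3)C(=O)CC[C@]2(c2ccccc2)O1` instead carries 3,5-dichlorophenyl in place of 4-nitrophenyl on an amide-type nitrogen in a ring. That step came from a different replacement and guides the new one only loosely, so a step of uncertain direction, within or modestly beyond the scatter, is expected. The estimate for compound 3 is 5000 nM, ranging from 1500 nM to 15000 nM. The expected step is a 1.7-fold lower number from compound 1 to compound 3 (0.24 log units; within the scatter).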

Compound 3, half-maximal inhibitory concentration: 6520 nM
Compound 3: the middle estimate sits 1.3-fold (0.12 log units) below what was measured, and the stated range covers the measured number.
By their numbers in this assay, from the lowest: compound 2; then compounds 3 and 1 (each within the scatter of the next).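

With a 1.3-fold lower number from compound 1 to compound 3 (0.13 log units; within the scatter) on the amide-type nitrogen, 3,5-dichlorophenyl and 4-nitrophenyl cannot be told apart. Pyridin-2-yl now stands apart from both, as a 4.7-fold higher number from compound 2 to compound 3 (0.67 log units; beyond the scatter) joins a 6.2-fold lower number from compound 1 to compound 2 (0.79 log units; beyond the scatter) as a second step beyond the scatter. No supporting evidence explains this difference.

An unsubstituted phenyl group or a pyridin-4-yl group on this nitrogen could help show whether the lower number goes with pyridin-2-yl specifically. On these data alone, how a phenyl group carrying an amine would compare remains open too.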